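A few compounds are considered here, and "the series" means these few. Any claim that something is new, unique, unknown or untested is made for them only; others in the source may bear on it.

In a physicochemical assay for lipophilicity, at pH 7.4 (a higher number here means a more lipophilic compound, a lower number a more polar compound), the measured compounds so far:
- compound 1 `CCc1ccc(N(CC(C)C)S(=O)(=O)c2ccc3c(c2)C(O)CC(C2CCOCC2)O3)cc1`: 4.12
- compound 2 `CCc1ccc(N(CC(C)C)S(=O)(=O)c2ccc3c(c2)CCC(C2CCOCC2)O3)cc1`: 5.38

Of these two, compound 2 stands higher, at 5.38. Compound 3 `CCc1ccc(N(CC(C)C)S(=O)(=O)c2ccc3c(c2)C(C)CC(C2CCOCC2)O3)cc1` departs from it by methyl in place of hydrogen on a saturated ring carbon. This is the ring carbon that carries the hydroxy in compound 1. Within the data shown here, the one measured step bearing on the change is hydrogen in place of hydroxy on that carbon, a number 1.26 log units higher from compound 1 to compound 2 (beyond the scatter). Among the measured compounds shown here, it shows that this assay can move widely with a change at this carbon, but it involves a different group, and no methyl step has been measured. A smaller, upward move is therefore expected, with a number 0.32 log units higher from compound 2 to compound 3 (beyond the scatter) as the estimated step. For compound 3 the expected value is 5.7, within an estimated range of 5.35 to 6.1.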

Compound 3, distribution coefficient: 5.71
Beside the measured number, compound 3's estimate is 0.01 log units below it; the range from low to high includes it.
By their numbers in this assay, from the lowest: compound 1; then compound 2; then compound 3.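

In this assay, methyl in place of hydrogen on this saturated ring carbon gives a number 0.33 log units higher from compound 2 to compound 3 (beyond the scatter) and so shows that a change at this position need not involve the hydroxy to move the number beyond the scatter. Methyl in place of hydroxy gives a number 1.59 log units higher from compound 1 to compound 3 (beyond the scatter) as the largest step in the series so far, and the larger part of that span is the step from hydroxy to hydrogen, with the step from hydrogen to methyl the smaller part. No measurement at hand accounts for either step.

Open, going by these compounds, is where ethyl, fluorine, an amine or a carboxylic acid on this carbon would fall relative to compound 1, compound 2 and compound 3. Also open, on these data alone, is whether the methyl step would keep its size on a different oxan-4-yl replacement or with other changes elsewhere on the shared core.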